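The source may report more compounds than this note shows. Statements on the series, on what has been measured and on what is new or still open speak of the compounds shown alone.

The measured compounds are:
compound 1, `Cc1c(C(=O)NCCCN2CCN(C)CC2)c(-c2cccc(N3CCN(c4ccc(NS(=O)(=O)c5cccc(OC(C)C)c5)cc4)CC3)c2)c(-c2ccc(Cl)cc2)n1C`, 2020 nM
compound 2, `Cc1cccc(S(=O)(=O)Nc2ccc(N3CCN(c4cccc(-c5c(C(=O)NCCCN6CCN(C)CC6)c(C)n(C)c5-c5ccc(Cl)cc5)c4)CC3)cc2)c1`, 689 nM
compound 3, `Cc1c(C(=O)NCCCN2CCN(C)CC2)c(-c2cccc(N3CCN(c4ccc(NS(=O)(=O)c5cccc(OC(F)(F)F)c5)cc4)CC3)c2)c(-c2ccc(Cl)cc2)n1C`, 763 nM

All three were tested in an assay for inhibition of Apoptosis regulator Bcl-2 (Homo sapiens), read by fluorescence polarization, with a stated time of 2 h; on this read-out lower numbers stand for stronger inhibition and higher numbers for weaker inhibition. On these numbers compound 1 stands highest of the three; compound 3 is nearest to it and compound 2 furthest from it. The unmeasured compound 4, `COc1cccc(S(=O)(=O)Nc2ccc(N3CCN(c4cccc(-c5c(C(=O)NCCCN6CCN(C)CC6)c(C)n(C)c5-c5ccc(Cl)cc5)c4)CC3)cc2)c1`, is derived from compound 1 by a single change, (methyl in place of isopropyl on an oxygen on an aromatic ring).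

Going by the values given here, two measured steps bear on this change, both starting from compound 1 and both altering the same group on the same aromatic ring. The first, a 2.9-fold lower number from compound 1 to compound 2 (0.47 log units; beyond the scatter), and the second, a 2.6-fold lower number from compound 1 to compound 3 (0.42 log units; beyond the scatter), are modest, beyond the scatter, and point in the same direction. Between compound 2 and compound 3 the step is a 1.1-fold higher number from compound 2 to compound 3 (0.04 log units; within the scatter), so the two replacements of the isopropoxy sit together. Methoxy is a third variant at the same place, and from the behaviour of compound 2 and compound 3 a modest lowering in this assay is expected, of a size near those two steps. Compound 4 is therefore estimated to give 900 nM, within a range of 450 nM to 1800 nM. The expected step is then a 2.2-fold lower number from compound 1 to compound 4 (0.35 log units; beyond the scatter).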

Compound 4, half-maximal inhibitory concentration: 802 nM
Estimate against measurement, compound 4: 1.1-fold (0.05 log units) above, within the range that was stated.
By their numbers in this assay, from the lowest: compounds 2, 3 and 4 (each within the scatter of the next); then compound 1.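

In this assay the change from isopropoxy to methoxy gives a 2.5-fold lower number from compound 1 to compound 4 (0.40 log units; beyond the scatter), so a third replacement at this place lowers the number by a modest step, and here the oxygen on the aromatic ring stays while only isopropyl gives way to methyl. Compound 4 also cannot be told apart from the other two replacements, with a 1.1-fold higher number from compound 3 to compound 4 (0.02 log units; within the scatter) and a 1.2-fold higher number from compound 2 to compound 4 (0.07 log units; within the scatter) both within the scatter, so methyl, methoxy and trifluoromethoxy form one group on this read-out. Compound 2 has no oxygen at this place while compound 3 and compound 4 do, and compound 1, which also has one, is the only compound set apart, so the oxygen alone does not decide the value among these four.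

Nothing shown here explains why the isopropoxy of compound 1 stands apart from the other three groups. The compounds shown leave open whether ethoxy, a longer chain on the same oxygen, would stay with methoxy or go with isopropoxy, and whether an amine or a carboxylic acid at this place would move the number beyond this group at all.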